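A few compounds are considered here, and "the series" means these few. Any claim that something is new, unique, unknown or untested is made for them only; others in the source may bear on it.

Compound 1 `Cc1nc(C(NC(=O)C(=O)Nc2ccc(C(F)(F)F)cc2)C2CCCCN2)sc1CO`: in an ADME assay on MT2 cells (Homo sapiens) for cytotoxicity, read by XTT assay, with a stated time of 4 days (a higher number here means that more compound is tolerated, a lower number that less compound is tolerated), compound 1 gives > 75500 nM, which is a limit of the assay, not a number.
Compound 2 `Cc1nc(C(NC(=O)C(=O)Nc2ccc(Cl)c(F)c2)C2CCCCN2)sc1CO`: in this assay compound 2 gives 77800 nM.

Compound 2 thus holds the only number shown; the other value is a limit. The step that the limit leaves unreadable from compound 1 to compound 2 cannot be read in size because of the limit of > 75500 nM in this assay, at which 1 of the 2 values shown sits.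

Compound 3 `Cc1nc(C(NC(=O)C(=O)NC2CCCCCC2)C2CCCCN2)sc1CO` differs from compound 2 by cycloheptyl in place of 4-chloro-3-fluorophenyl on an amide-type nitrogen. For the measured compounds named here, no measured step in this set bears on such a swap of an aromatic ring for a saturated one; the only measured step is unreadable, so the data give no direction and no size to carry over. The expectation therefore rests on compound 2 alone, with a wide range. Compound 3 is expected to give 70000 nM in this assay, with a range from 25000 nM to 150000 nM. This expected value means a step of a 1.1-fold lower number from compound 2 to compound 3 (0.05 log units; within the scatter), which may well come back as a limit again.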

Compound 3, half-maximal cytotoxic concentration: > 90000 nM
Compound 3: no number, only a limit; the forecaster's own chance of this, stated with the estimate: 50%; middle value at least 1.2-fold (0.10 log units) from the limit.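

In this assay compound 3 gives > 90000 nM, which is a limit of the assay and not a number. For the compounds shown here, the change on the amide-type nitrogen gives an at least 1.1-fold higher number from compound 2 to compound 3 (0.06 log units; that floor lies within the scatter), so this position takes a seven-membered non-aromatic ring of carbon only, with no sign of less compound being tolerated than with the 4-chloro-3-fluorophenyl group. The step between compound 1 and compound 3 cannot be read, as both ends are limits.

From the compounds shown here alone, the actual number for compound 3 stays unknown, and with it any true ranking of the three compounds. Also open, going by these compounds, is whether an amine or a carboxylic acid on the ring at this nitrogen, or an open hexyl chain in place of the cycloheptyl, would be tolerated as well.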